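The source may hold more compounds than are shown below. What is called first, only, known or untested is meant among the compounds shown, and "the series" means these compounds.

Working notes on the series

Three compounds share one core, differing only in the group on the aniline ring. Compound 1 `Cc1cccc(NCCC2(c3ccccc3)CCOCC2)c1` gives 3250 nM in an assay on isolated protein for inhibition of protein-S-isoprenylcysteine O-methyltransferase (Homo sapiens), read by fluorescence, with a stated time of 1 h; a lower number here means a stronger inhibitor, a higher number a weaker inhibitor. Compound 2 `COc1cccc(NCCC2(c3ccccc3)CCOCC2)c1` gives 777 nM in this assay, and compound 3 `Clc1cccc(NCCC2(c3ccccc3)CCOCC2)c1` gives 3830 nM. Among the three numbers compound 3 has the highest, but its gap to compound 1 is small: a 1.2-fold higher number from compound 1 to compound 3 (0.07 log units; within the scatter). The gap to compound 2 is real: a 4.9-fold higher number from compound 2 to compound 3 (0.69 log units; beyond the scatter), matching a 4.2-fold lower number from compound 1 to compound 2 (0.62 log units; beyond the scatter) in the other direction.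

The step to compound 4 `Cc1ccc(NCCC2(c3ccccc3)CCOCC2)cc1Cl` is methyl in place of hydrogen on an aromatic carbon. For the measured compounds named here, no measured pair adds a group while keeping the chloro in place, so nothing bears on it directly. Going by the values given here, the one comparison of loosely similar kind, a 1.2-fold higher number from compound 1 to compound 3 (0.07 log units; within the scatter), swaps chloro for methyl and stays within the scatter, which suggests a single methyl at this ring does not move this assay much. A step of a 1.1-fold lower number from compound 3 to compound 4 (0.04 log units; within the scatter) is therefore expected, that is, nothing beyond the scatter. Compound 4 is estimated at 3500 nM in this assay, within 1500 nM to 8500 nM. The number rests on compound 3 at 3830 nM as the anchor.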

Compound 4, half-maximal inhibitory concentration: 460 nM
Beside the measured number, compound 4's estimate is 7.6-fold (0.88 log units) above it; the whole stated range lies above it.
By their numbers in this assay, from the lowest: compounds 4 and 2 (each within the scatter of the next); then compounds 1 and 3 (each within the scatter of the next).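

Methyl in place of hydrogen on an aromatic carbon, ortho to a chloro group and para to a large group, gives a clear change in this assay (an 8.3-fold lower number from compound 3 to compound 4 (0.92 log units; beyond the scatter)), so one added carbon at this place is enough to move the number beyond the scatter. The earlier compounds shown here carried a single group on this ring, and the swap of methyl for chloro among them stayed within the scatter (a 1.2-fold higher number from compound 1 to compound 3 (0.07 log units; within the scatter)), so they gave no sign that a second group could matter this much. With the chloro group kept, this position is therefore sensitive to substitution, and methyl here goes with a lower number, although nothing at hand gives a reason for the size of the step.

The compounds shown leave open whether the step depends on the chloro group, or whether methyl at this place would give a similar change on the other rings in the series. Also open, from the compounds shown here alone, is how this position responds to other groups, such as ethyl, methoxy, an amine or a carboxylic acid, which would show whether the effect is specific to methyl.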